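Swapping chloro for fluoro in a whole-animal modulator series

A few compounds are considered here, and "the series" means these few. Any claim that something is new, unique, unknown or untested is made for them only; others in the source may bear on it.

Measured compounds and values:
Compound 1, `Cc1nn(C)c2c1C(c1cccc(Cl)c1)=NCCN2C`: in a functional assay on the whole organism for positive allosteric modulation, with Rattus norvegicus as the target (on this read-out higher numbers stand for an effect only at larger amounts of compound and lower numbers for an effect already at smaller amounts), compound 1 gives 0.63 mg/kg.
Compound 2, `CCN1CCN=C(c2cccc(Cl)c2)c2c(C)nn(C)c21`: compound 2 gives 0.63 mg/kg.
Compound 3, `Cc1nn(C)c2c1C(c1cccc(Cl)c1)=NCCN2CCCN(C)C`: compound 3 gives only a limit of the assay, > 10 mg/kg.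

Compound 3 thus sits at the limit (the limit of > 10 mg/kg in this assay, at which 1 of the 3 values shown sits), the one result of the three that is not a number. Compound 4, `Cc1nn(C)c2c1C(c1cccc(F)c1)=NCCN2CCCN(C)C`, differs from compound 3 by fluoro in place of chloro on an aromatic carbon; cut one bond further out, the change reads 3-chlorophenyl to 3-fluorophenyl. Among the compounds with values here, none of the measured steps touches this part of the molecule: an at least 15-fold higher number from compound 1 to compound 3 (1.20 log units; beyond the scatter) and an at least 15-fold higher number from compound 2 to compound 3 (1.20 log units; beyond the scatter) both concern the chain on the ring nitrogen, as does no change at the digits printed from compound 1 to compound 2 (within the scatter). They offer no guide to a chloro-to-fluoro swap. With nothing pointing to a shift, the expectation for compound 4 is a result close to where compound 3 stands, most likely again a limit rather than a number, and the expected step of a number no higher from compound 3 to compound 4 (the limit leaves the size open) is none beyond the scatter. Compound 4 is expected to give 10 mg/kg, between 3 mg/kg and 30 mg/kg.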

Compound 4, minimum effective dose: > 10 mg/kg
Compound 4 ended at the assay's limit; the forecaster's own chance of this, stated with the estimate: 65%; the middle value lies on the limit itself.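

Compound 3 and compound 4 both end at a limit rather than a number, so the step between them cannot be read: the limit of > 10 mg/kg in this assay, at which 2 of the 4 values shown sit.

The compounds shown leave open whether 3-fluorophenyl in place of 3-chlorophenyl changes the dose needed for an effect, and what dose either compound would need.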